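Fluoro to Methoxy on a Pyridyl Amine Substituent

This account rests on a few compounds, and the source may have more. Where it says the series, first, only, none or still open, it means among the compounds named here.

Of the compounds shown here, three sharing one core have been measured in a functional assay on HCT-116 cells (Homo sapiens) for cytotoxicity, read by sulforhodamine B assay, with a stated time of 72 h; on this read-out higher numbers stand for weaker inhibition and lower numbers for stronger inhibition. Compound 1 `CCS(=O)(=O)Nc1cc(-c2ccc3ncnc(Nc4ccc(F)cc4)c3c2)cnc1OC` gives 3160 nM. Compound 2 `CCS(=O)(=O)Nc1cc(-c2ccc3ncnc(Nc4ccc(OC)cc4)c3c2)cnc1OC` differs from it by methoxy in place of fluoro on an aromatic carbon, and in this assay compound 2 gives 3490 nM; the step is a 1.1-fold higher number from compound 1 to compound 2 (0.04 log units; within the scatter). Compound 3 `CCS(=O)(=O)Nc1cc(-c2ccc3ncnc(Nc4ccc(F)nc4)c3c2)cnc1OC` carries a different ring on the amine nitrogen, the difference being (6-fluoropyridin-3-yl in place of 4-fluorophenyl on a nitrogen on an aromatic ring), and in this assay compound 3 gives 7620 nM. The steps to it are a 2.4-fold higher number from compound 1 to compound 3 (0.38 log units; beyond the scatter) and a 2.2-fold higher number from compound 2 to compound 3 (0.34 log units; beyond the scatter).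

Compound 4 `CCS(=O)(=O)Nc1cc(-c2ccc3ncnc(Nc4ccc(OC)nc4)c3c2)cnc1OC` has not yet been measured. It differs from compound 3 by methoxy in place of fluoro on an aromatic carbon. For the measured compounds named here, this is the same kind of change as the one from compound 1 to compound 2, but the place is not identical: in compound 1 the fluoro sits on an aromatic carbon of a six-membered aromatic ring of carbon only, para to a large group, whereas in compound 3 it sits on an aromatic carbon of a six-membered aromatic ring with 1 nitrogen, next to the ring nitrogen, para to a large group. Going by the values given here, the one earlier example of this kind of change moved the number only a little, a 1.1-fold higher number from compound 1 to compound 2 (0.04 log units; within the scatter), within the scatter. On that single precedent the step from compound 3 to compound 4 in this assay is expected to be small, about a 1.0-fold higher number from compound 3 to compound 4 (0.02 log units; within the scatter). Compound 4 is therefore estimated to give about 8000 nM in this assay, most likely between 4000 nM and 18000 nM. Among the compounds with values here, with only one prior instance, this expectation rests on thin ground.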

Compound 4, half-maximal inhibitory concentration: 6910 nM
Estimate against measurement, compound 4: 1.2-fold (0.06 log units) above; the measured number falls inside the stated range.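

In this assay, putting methoxy in place of fluoro made no difference beyond the scatter on either amine ring, whether that ring had carbon only or one nitrogen, and the new step, a 1.1-fold lower number from compound 3 to compound 4 (0.04 log units; within the scatter), agrees with the earlier one: the same change on two cores in this assay, a 1.1-fold higher number (0.04 log units; within the scatter) from compound 1 to compound 2 and a 1.1-fold lower number (0.04 log units; within the scatter) from compound 3 to compound 4, 1.2-fold (0.09 log units) apart, within the scatter of two such steps With methoxy on the ring in both compounds, the exchange of 4-methoxyphenyl for 6-methoxypyridin-3-yl gives a 2.0-fold higher number from compound 2 to compound 4 (0.30 log units; within the scatter), which stays within the scatter, while the comparison with the fluorinated compound without a ring nitrogen gives a 2.2-fold higher number from compound 1 to compound 4 (0.34 log units; beyond the scatter), a modest step beyond it. This shows that the swap carried over between these two closely related compounds in one cell assay, but two pairs cannot show that it would hold on other cores, and they give no reason why the swap changes so little.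

What the compounds leave open is whether other groups in the same place, such as an amine, a carboxylic acid or a longer chain like ethoxy, would also leave the number unchanged. From the compounds shown here alone, it also remains open whether the same swap stays this quiet on a compound with a much lower number, since all four compounds here sit in a narrow band of values.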